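Vero cell cytotoxicity: three analogues at the assay limit

The source may hold more compounds than are shown below. What is called first, only, known or untested is meant among the compounds shown, and "the series" means these compounds.

compound 1 `O=C(OC1CCC(CN2CCN(c3cc(=O)c4cc(C(F)(F)F)cc([N+](=O)[O-])c4s3)CC2)CC1)C1CCC1`: > 64 ug/mL
compound 2 `CC(C)S(=O)(=O)OC1CCC(CN2CCN(c3cc(=O)c4cc(C(F)(F)F)cc([N+](=O)[O-])c4s3)CC2)CC1`: > 64 ug/mL
compound 3 `O=C(OC1CCC(CN2CCN(c3cc(=O)c4cc(C(F)(F)F)cc([N+](=O)[O-])c4s3)CC2)CC1)c1ccco1`: > 64 ug/mL

In an ADME assay on Vero cells (Chlorocebus sabaeus) for cytotoxicity, read by MTT assay, with a stated time of 48 h (a lower number here means a stronger inhibitor, a higher number a weaker inhibitor), compound 1 gives > 64 ug/mL, which is a limit of the assay and not a number. Compound 2 likewise sits at a limit, > 64 ug/mL. Compound 3 also returns a limit, > 64 ug/mL. Compound 1 therefore cannot be placed against the other two beyond the shared fact of the limit of > 64 ug/mL in this assay, at which 3 of the 3 values shown sit; the steps a step that the two limits leave unreadable from compound 1 to compound 2, a step that the two limits leave unreadable from compound 1 to compound 3 and a step that the two limits leave unreadable from compound 2 to compound 3 give no readable size in either direction.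

The next compound, compound 4 `CS(=O)(=O)NC1CCC(CN2CCN(c3cc(=O)c4cc(C(F)(F)F)cc([N+](=O)[O-])c4s3)CC2)CC1`, differs from compound 1 in one place: methanesulfonamido in place of (cyclobutylcarbonyl)oxy on a saturated ring carbon. Among the compounds with values here, none of the measured steps touches this kind of change directly; the closest are the two swaps at the same oxygen on the saturated ring carbon, from cyclobutylcarbonyl to isopropylsulfonyl and to (furan-2-yl)carbonyl, and both left the limit untouched. With every measured value resting at the limit of > 64 ug/mL in this assay, at which 3 of the 3 values shown sit, no step size can be projected, and no move beyond the scatter is expected from a number no higher from compound 1 to compound 4 (the limit leaves the size open).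

Compound 4 is accordingly expected to give about 64 ug/mL in this assay, with a range of 32 ug/mL to 128 ug/mL, most likely reported again only as a limit.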

Compound 4, half-maximal inhibitory concentration: 48.5 ug/mL
Compound 4: middle estimate off by 1.3-fold (0.12 log units), on the high side; low and high end bracket the measured number.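

Compound 4 is the only compound shown that returns a number and not a limit in this assay: compound 4 gives 48.5 ug/mL, with methanesulfonamido on the saturated ring carbon of the six-membered ring of carbon only. Set against the three oxygen-linked groups, the change reads as an at least 1.3-fold lower number from compound 1 to compound 4 (0.12 log units; that floor lies within the scatter), as an at least 1.3-fold lower number from compound 3 to compound 4 (0.12 log units; that floor lies within the scatter) and as an at least 1.3-fold lower number from compound 2 to compound 4 (0.12 log units; that floor lies within the scatter); each of these is a floor only, so no shift beyond the scatter is shown, and the steps among compounds 1, 2 and 3 still cannot be read. The comparison rests on one measured number, and the other three compounds share a single limit: the limit of > 64 ug/mL in this assay, at which 3 of the 4 values shown sit.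

From the compounds shown here alone, how far the true gap between compound 4 and the other three extends remains open, since only its floor is known. An amine or an acetamido group on the same saturated ring carbon would show whether a number in place of a limit goes with the nitrogen link itself or with the methanesulfonyl part.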